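Aryl versus ester on the triazole chain: cytotoxicity in MT4 cells

A few compounds are considered here, and "the series" means these few. Any claim that something is new, unique, unknown or untested is made for them only; others in the source may bear on it.

Going by the values given here, compound 3 `CCOC(=O)CCn1cc(CNC(=O)c2cnc(Nc3ccc(C#N)cc3)cc2Oc2c(C)cc(C)cc2C)nn1` gives 21500 nM in an ADME assay on MT4 cells (Homo sapiens) for cytotoxicity, read by MTT assay, with a stated time of 5 days (a higher number here means that more compound is tolerated, a lower number that less compound is tolerated), the lowest of the three numbers so far. Compound 2 `Cc1cc(C)c(Oc2cc(Nc3ccc(C#N)cc3)ncc2C(=O)NCc2cn(CC(N)=O)nn2)c(C)c1` gives 24000 nM and compound 1 `Cc1ccc(Cn2cc(CNC(=O)c3cnc(Nc4ccc(C#N)cc4)cc3Oc3c(C)cc(C)cc3C)nn2)cc1` gives 165000 nM; the gap between compound 2 and compound 3 sits within the scatter, while a 7.7-fold lower number from compound 1 to compound 3 (0.89 log units; beyond the scatter) and a 6.9-fold lower number from compound 1 to compound 2 (0.84 log units; beyond the scatter) are beyond it. Compound 4 `Cc1cc(C)c(Oc2cc(Nc3ccc(C#N)cc3)ncc2C(=O)NCc2cn(Cc3ccccc3C)nn2)c(C)c1` carries 2-methylphenyl in place of (ethoxycarbonyl)methyl on a saturated chain carbon bound to an aromatic nitrogen. Among the compounds with values here, the step bearing on this is the reverse of the one from compound 1 to compound 3, where a 7.7-fold lower number from compound 1 to compound 3 (0.89 log units; beyond the scatter) accompanied the move from 4-methylphenyl to (ethoxycarbonyl)methyl; 2-methylphenyl is not the same group, so the size is uncertain. A higher number is expected for compound 4, a 5.1-fold higher number from compound 3 to compound 4 (0.71 log units; beyond the scatter), giving an estimate of 110000 nM with a range from 35000 nM to 250000 nM.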

Compound 4, half-maximal cytotoxic concentration: >= 164000 nM
Compound 4: no number, only a limit; the forecaster's own chance of this, stated with the estimate: 10%; at least 1.4-fold (0.17 log units) between middle value and limit.
By their numbers in this assay, from the lowest: compounds 3 and 2 (each within the scatter of the next); then compound 1.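

On the saturated chain carbon bound to an aromatic nitrogen, 2-methylphenyl gives an at least 7.6-fold higher number from compound 3 to compound 4 (0.88 log units; beyond the scatter) and an at least 6.8-fold higher number from compound 2 to compound 4 (0.83 log units; beyond the scatter) in this assay. The higher tolerance seen with 4-methylphenyl in compound 1 is therefore not confined to one methylphenyl isomer: compounds 1 and 4 both stand clear of compounds 2 and 3, and no compound shown goes against this. The step between compound 1 and compound 4 cannot be read, as compound 4 gives only a limit: the limit of >= 164000 nM in this assay, at which 1 of the 4 values shown sits.

On these data alone, whether the two methylphenyl groups differ at all stays open. Also open, as far as these compounds go, is where an unsubstituted phenyl, an amine or a carboxylic acid at this place would fall.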